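Ester-to-amide swap on the cyanophenylamino series

A few compounds are considered here, and "the series" means these few. Any claim that something is new, unique, unknown or untested is made for them only; others in the source may bear on it.

Measured so far, in a physicochemical assay for lipophilicity, read by HPLC, measured as octanol-water partition, with a stated time of 24 h, at pH 7.4; on this read-out lower numbers stand for lower lipophilicity and higher numbers for higher lipophilicity:
compound 1 `Cc1cc(CCC#N)cc(C)c1Oc1cc(Nc2ccc(C#N)cc2)c(N)cc1C(=O)NC1CC1`: 2.61
compound 2 `Cc1cc(CCC#N)cc(C)c1Oc1cc(Nc2ccc(C#N)cc2)c(N)cc1COC(=O)C1CC1`: 2.51
compound 3 `COC(=O)c1cc(N)c(Nc2ccc(C#N)cc2)cc1Oc1c(Br)cc(CCC#N)cc1OC`: 2.85

Compound 3 gives the highest of the three numbers in this assay. Against compound 1 it sits within the scatter; against compound 2 it lies beyond the scatter. For the measured compounds named here, the one measured single-point step, a number 0.10 log units lower from compound 1 to compound 2 (within the scatter), exchanges one carbonyl-bearing group for another and lands within the scatter.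

Compound 4 `CNC(=O)c1cc(N)c(Nc2ccc(C#N)cc2)cc1Oc1c(Br)cc(CCC#N)cc1OC` is not yet measured. It differs from compound 3 by methylamino in place of methoxy on a carbonyl carbon; cut one bond further out, the exchange reads methoxycarbonyl to methylcarbamoyl.

Going by the values given here, no measured step in this assay covers this exact exchange. The step from compound 1 to compound 2 is the nearest relative, swapping a carbamoyl for an oxycarbonyl arrangement in the other direction, and it stayed within the scatter, so the measured record alone gives no firm size. Still, a donor replaces an acceptor on the carbonyl carbon, and a modest move to a lower number is the working expectation, with a wide range on either side. Compound 4 is thus expected at 2.3, between 1.8 and 2.8, which would mean a step of a number 0.55 log units lower from compound 3 to compound 4 (beyond the scatter).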

Compound 4, partition coefficient: 3.16
Estimate against measurement, compound 4: 0.86 log units below; the measured number lies above the stated range.
By their numbers in this assay, from the lowest: compounds 2, 1 and 3 (each within the scatter of the next, the first and the last beyond it); then compound 4.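

On a carbonyl carbon whose other neighbours are aromatic carbon, methylamino in place of methoxy gives in this assay a step of a number 0.31 log units higher from compound 3 to compound 4 (beyond the scatter) and thus shows that this exchange moves the read-out upward, even though methylamino brings 1 hydrogen-bond donor and methoxy takes away 1 hydrogen-bond acceptor. For the compounds shown here, the only earlier step between compounds differing in one place, a number 0.10 log units lower from compound 1 to compound 2 (within the scatter) for a different exchange on an aromatic carbon, left the size of any change at a carbonyl-bearing group unsettled, whereas this pair gives a step beyond the scatter at this position. Nothing at hand bears on why the number moves in this direction.

The compounds shown leave open whether dimethylamino, ethylamino or a free carboxylic acid on the same carbonyl carbon would continue this trend or break from it. They also leave open whether methylamino in place of methoxy gives a step of the same direction and size on the core of compound 1, since one matched pair carries this exchange and it cannot by itself establish a pattern.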